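The compounds below may be only part of what the source reports. "The series", "measured", "known", "first", "only" and "open" are said of these compounds alone.

Working notes on the series in a functional assay on RAW264.7 cells (Mus musculus) for inhibition, read by Griess assay; on this read-out lower numbers stand for stronger inhibition and higher numbers for weaker inhibition. Of the compounds shown here, three are measured so far, and none gives a number. Compound 1 `COc1c(O[C@@H]2O[C@H](C(=O)O)[C@@H](O)[C@H](O)[C@H]2O)cc(O)c2c1O[C@H](c1ccccc1O)CC2=O` reaches only a limit of this assay, > 30000 nM. Compound 2 `COc1cc(O)c2c(c1OC)O[C@H](c1cc(O)ccc1O[C@@H]1O[C@H](CO)[C@@H](O)[C@H](OC(=O)c3ccc(O)cc3)[C@H]1O)CC2=O` likewise stops at a limit of this assay, > 30000 nM. Compound 3 `COC(=O)[C@H]1O[C@@H](Oc2c(O)cc(O)c3c(=O)cc(-c4ccccc4)oc23)[C@H](O)[C@@H](O)[C@@H]1O` also gives only a limit in this assay, > 30000 nM. Going by the values given here, compound 3 therefore stands where the other two stand, at the limit of > 30000 nM in this assay, at which 3 of the 3 values shown sit; there is no numeric value among the three to set one above another, and no pair of measured compounds differs in a single place, so no measured step is available.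

Compound 4 `O=C(O)[C@H]1O[C@@H](Oc2c(O)cc(O)c3c(=O)cc(-c4ccccc4)oc23)[C@H](O)[C@@H](O)[C@@H]1O` has not yet been measured in this assay. Its difference from compound 3 is hydrogen in place of methyl on an oxygen next to a carbonyl group; cut one bond further out, the methoxycarbonyl of compound 3 becomes the carboxy of compound 4. With compound 3 sitting at a limit, the step that the limit leaves unreadable from compound 3 to compound 4 is expected to be none beyond the scatter, in no particular direction. Compound 4 is accordingly expected to give 50000 nM in this assay, estimated within 15000 nM to 200000 nM, and most likely to return only a limit, as the three measured compounds do.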

Compound 4, half-maximal inhibitory concentration: > 30000 nM
Compound 4: a limit, no number; the forecaster's own chance of this, stated with the estimate: 85%; the middle value does not contradict the limit.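

No step can be read from compound 3 to compound 4, methoxycarbonyl to carboxy, since both stop at a limit: the limit of > 30000 nM in this assay, at which 4 of the 4 values shown sit.

As far as these compounds go, what remains open is whether that change affects inhibition in this assay at all, and which structural change, if any, would bring a compound of this series to a numeric value.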